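The compounds below may be only part of what the source reports. "The series", "measured", "known", "first", "only" and "open" are said of these compounds alone.

Within the data shown here, compound 1 `C=CCOC(=O)SCCCCCCNC(=O)c1cc(-c2ccncc2)n[nH]1` is the only compound with a numbered result in a functional assay on MCF7 cells (Homo sapiens) for inhibition, read by MTT assay, with a stated time of 96 h (on this read-out higher numbers stand for weaker inhibition of growth and lower numbers for stronger inhibition of growth), where compound 1 gives 12600 nM. Compound 2 `O=C(NCCCCCCS)c1cc(C2CCCCC2)n[nH]1` reaches only a limit of the assay, > 50000 nM, in this assay. Compound 3 `CC(C)C(=O)SCCCCCCNC(=O)c1cc(-c2ccncc2)n[nH]1` differs from compound 1 by isopropyl in place of allyloxy on a carbonyl carbon, the change sitting on a carbonyl carbon whose other neighbours are sulfur. Among the measured compounds shown here, no measured pair shows a step of this kind, so the step from compound 1 to compound 3 is expected to stay within the usual scatter, with no clear direction, estimated as a 1.3-fold lower number from compound 1 to compound 3 (0.10 log units; within the scatter). Compound 3 is therefore estimated at 10000 nM, expected between 3000 nM and 40000 nM.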

Compound 3, concentration for 50% growth inhibition: 15200 nM
The estimate for compound 3 lay 1.5-fold (0.18 log units) below the measured number, within the range that was stated.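

Isopropyl in place of allyloxy on a carbonyl carbon gives a 1.2-fold higher number from compound 1 to compound 3 (0.08 log units; within the scatter) in this assay. At this position, on a carbonyl carbon whose other neighbours are sulfur, the two compounds cannot be told apart, even though the oxygen and the double bond of allyloxy are gone. Nothing shown bears on a cause for this result. Going by these compounds, whether an amine, a carboxylic acid or a longer chain on this carbonyl carbon would also stay within the scatter of compound 1 remains open.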